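The source may hold more compounds than are shown below. What is called first, only, known or untested is meant among the compounds shown, and "the series" means these compounds.

Of the compounds shown here, two of a shared core have been measured in a functional assay on MCF7 cells (Homo sapiens) for cytotoxicity, read by MTT assay, with a stated time of 72 h; a lower number here means a stronger inhibitor, a higher number a weaker inhibitor. Compound 1 `Cc1ccc(-n2nc(C(=O)Nc3ccc(Oc4ncnc5[nH]ccc45)cc3)c(C)cc2=O)cc1` stands lowest of the two numbers; in this assay compound 1 gives 3620 nM. Compound 2 `Cc1cc(=O)n(-c2ccccc2OC(F)(F)F)nc1C(=O)Nc1ccc(Oc2ncnc3[nH]ccc23)cc1` carries a 2-(trifluoromethoxy)phenyl in place of the 4-methylphenyl on an aromatic nitrogen, and in this assay compound 2 gives 32000 nM. That step, an 8.8-fold higher number from compound 1 to compound 2 (0.95 log units; beyond the scatter), is the only one measured. Compound 3 `Cc1ccc(-n2nc(C(=O)Nc3ccc(Oc4ncnc5[nH]ccc45)c(F)c3)c(C)cc2=O)cc1` has not yet been measured. It differs from compound 1 by fluoro in place of hydrogen on an aromatic carbon. For the measured compounds named here, the one measured step concerns a different place in the structure, and its size gives no direct guide to this change. With nothing pointing either way, no step beyond the scatter is expected here. In this assay compound 3 is expected to give 3000 nM, with a range from 1000 nM to 9000 nM. The step that this estimate means, a 1.2-fold lower number from compound 1 to compound 3 (0.08 log units; within the scatter), is expected to stay within the scatter.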

Compound 3, half-maximal inhibitory concentration: 18900 nM
Estimate against measurement, compound 3: 6.3-fold (0.80 log units) below; the whole stated range lies below it.
By their numbers in this assay, from the lowest: compound 1; then compounds 3 and 2 (each within the scatter of the next).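

In this assay, placing a single fluoro on this aromatic carbon, ortho to a large group and meta to a large group, gives a 5.2-fold higher number from compound 1 to compound 3 (0.72 log units; beyond the scatter). For the compounds shown here, the only earlier step concerned the group on the aromatic nitrogen, so this is the first sign that a different place in the structure also responds to change, and that one added heavy atom is enough for a step beyond the scatter. No measurement shown here bears on why the number rises.

Going by these compounds, what remains open is whether any replacement for hydrogen on this carbon raises the number, or whether the rise is particular to fluoro. A chlorine atom, a methyl group or a methoxy group on the same carbon would help to separate these two readings.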